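Morpholin-4-yl amide in a series stuck at its limit

The source may report more compounds than this note shows. Statements on the series, on what has been measured and on what is new or still open speak of the compounds shown alone.

In a functional assay on HL-60 cells (Homo sapiens) for antiproliferative activity, read by MTT assay, with a stated time of 24 h (a lower number here means a stronger inhibitor, a higher number a weaker inhibitor), three compounds have been read. Compound 1 `CCCCNC(=O)COc1ccc(C(=O)c2c(CCCC)oc3ccccc23)cc1` gives > 50000 nM, which is a limit. Compound 2 `CCCCc1oc2ccccc2c1C(=O)c1ccc(OCC(=O)N2CCCC2)cc1` gives > 50000 nM, also a limit. Compound 3 `CCCCNC(=O)CCCOc1ccc(C(=O)c2c(CCCC)oc3ccccc23)cc1` gives > 50000 nM, again a limit, so it stands with the other two: the limit of > 50000 nM in this assay, at which 3 of the 3 values shown sit. Unmeasured compound 4 `CCCCc1oc2ccccc2c1C(=O)c1ccc(OCCCC(=O)N2CCOCC2)cc1` differs from compound 3 as follows: morpholin-4-yl in place of butylamino on a carbonyl carbon. The closest measured change is a step that the two limits leave unreadable from compound 1 to compound 2, also a replacement of butylamino on a carbonyl carbon. The chain change, a step that the two limits leave unreadable from compound 1 to compound 3, is equally without a size. With no readable size behind it, the expected move is a step that the limit leaves unreadable from compound 3 to compound 4, with no direction expected beyond the scatter. The estimate for compound 4 is 60000 nM, with an expected range from 25000 nM to 150000 nM.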

Compound 4, half-maximal inhibitory concentration: 34100 nM
Estimate against measurement, compound 4: 1.8-fold (0.25 log units) above, and the stated range covers the measured number.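

In this assay compound 4 is the only compound shown that reads as a number and not as a limit, while the others remain at a limit: the limit of > 50000 nM in this assay, at which 3 of the 4 values shown sit.

On the carbonyl carbon, morpholin-4-yl in place of butylamino gives an at least 1.4-fold lower number from compound 3 to compound 4 (0.16 log units; that floor lies within the scatter), so this change has only a floor and no measured size. Compound 4 also shows an at least 1.4-fold lower number from compound 2 to compound 4 (0.16 log units; that floor lies within the scatter) and an at least 1.4-fold lower number from compound 1 to compound 4 (0.16 log units; that floor lies within the scatter), while the steps among the three earlier compounds cannot be read.

As far as these compounds go, whether piperidin-1-yl or piperazin-1-yl on the same carbonyl carbon also gives a number stays open. So does the reading of morpholin-4-yl on the chain of compound 1.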